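Chloro added to the benzylthio aryl of compound 2

This account rests on a few compounds, and the source may have more. Where it says the series, first, only, none or still open, it means among the compounds named here.

Compound 2, `Cn1c(=O)c2c(nc(SCc3ccccc3)n2C)n(C)c1=O`, holds the lowest of the two numbers recorded so far in an assay on membranes from brain for displacement of a labelled ligand from adenosine receptor A1 (Rattus norvegicus) (a higher number here means a weaker inhibitor, a lower number a stronger inhibitor), where compound 2 gives 4320 nM. Among the compounds with values here, the only other measured member is compound 1, `Cn1c(=O)c2c(nc(CSc3ccc(Cl)cc3)n2C)n(C)c1=O`, which in this assay gives 20800 nM, a clearly weaker result that lies beyond the scatter; compound 1 carries a different linker between the core and the aryl ring, so no single-point comparison to compound 2 exists.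

Compound 3, `Cn1c(=O)c2c(nc(SCc3ccc(Cl)cc3)n2C)n(C)c1=O`, differs from compound 2 in one place: chloro in place of hydrogen on an aromatic carbon, on an aromatic carbon of a six-membered aromatic ring of carbon only, para to a large group. Within the data shown here, no measured pair isolates this change. The two numbers in hand give no reason to expect a large shift; a small step toward weaker binding, or none beyond the scatter, is the working expectation. Compound 3 is therefore expected to give about 6000 nM in this assay, within a range of 2000 nM to 18000 nM. The expected step from compound 2 to compound 3 is a 1.4-fold higher number from compound 2 to compound 3 (0.14 log units; within the scatter).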

Compound 3, inhibition constant: 90000 nM
For compound 3 the middle estimate is 15-fold (1.18 log units) below the measured one, outside the stated range (above it).
By their numbers in this assay, from the lowest: compound 2; then compound 1; then compound 3.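

In this assay, within the data shown here, the change from phenyl to 4-chlorophenyl on the benzylthio group is a large loss, with a 21-fold higher number from compound 2 to compound 3 (1.32 log units; beyond the scatter) as the first step that isolates a single change. The position para to a large group on this six-membered aromatic ring is therefore not a neutral place for substitution in this series, since chloro in place of hydrogen, a change of one heavy atom, moves the number well beyond the scatter. Nothing available explains this step, so the compounds give only its size and direction.

Whether the loss belongs to chloro alone or extends to other groups at this place, such as methoxy, methyl, an amine or a carboxylic acid, remains open in the compounds shown. Also open, going by these compounds, is whether the same change from hydrogen to chloro carries the same size on the reversed linker of compound 1, and whether a longer chain between the core and the aryl ring would alter the response to this substitution.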